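A few compounds are considered here, and "the series" means these few. Any claim that something is new, unique, unknown or untested is made for them only; others in the source may bear on it.

Measured compounds:
compound 1 `CCOc1nc2ccccn2c(=N)c1S(=O)(=O)c1ccccc1`: 12 nM
compound 2 `C/N=c1/c(S(=O)(=O)c2ccccc2)c(SC)nc2ccccn12`: 120 nM

In an assay on HeLa cells for displacement of a labelled ligand from 5-hydroxytryptamine receptor 6 (Homo sapiens) (a lower number here means a stronger inhibitor, a higher number a weaker inhibitor), compound 1 gives 12 nM, the lower of the two numbers; compound 2 gives 120 nM, a gap well beyond the scatter. Compound 3 `CCNc1nc2ccccn2c(=N)c1S(=O)(=O)c1ccccc1` is not yet measured. It differs from compound 1 by ethylamino in place of ethoxy on an aromatic carbon. For the measured compounds named here, no measured pair shows this exchange, so the size of the step is open. The step from compound 1 to compound 3 is expected to be small, a 1.3-fold higher number from compound 1 to compound 3 (0.10 log units; within the scatter), likely within the scatter. Compound 3 is therefore expected at 15 nM, in the range 4 nM to 60 nM.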

Compound 3, half-maximal inhibitory concentration: 2 nM
Estimate against measurement, compound 3: 7.5-fold (0.88 log units) above; measured number below the stated range.
By their numbers in this assay, from the lowest: compound 3; then compound 1; then compound 2.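

In this assay ethylamino in place of ethoxy gives a 6.0-fold lower number from compound 1 to compound 3 (0.78 log units; beyond the scatter) so this position, on an aromatic carbon next to the ring nitrogen, responds to an exchange that keeps 3 heavy atoms and swaps oxygen for nitrogen. The exchange also adds a hydrogen-bond donor, and this single pair cannot separate that from the change of atom. Nothing measured here accounts for the step. Still open, as far as these compounds go, is how dimethylamino, which has no amine hydrogen, or a longer chain such as propylamino would behave at this position.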